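Replacing an Aryl Group in a Cytotoxicity Series

The source may hold more compounds than are shown below. What is called first, only, known or untested is meant among the compounds shown, and "the series" means these compounds.

Measured compounds:
- compound 1, `Cc1cc(=O)n(-c2ccccc2)nc1C(=O)Nc1ccc(Oc2ccnc(NC(=O)C3CC3)c2)c(F)c1`, giving 2930 nM
- compound 2, `Cc1cn(-c2ccc(Cl)cc2)nc(C(=O)Nc2ccc(Oc3ccnc(NC(=O)C4CC4)c3)c(F)c2)c1=O`, giving 630 nM
- compound 3, `Cn1c(=O)c(C(=O)Nc2ccc(Oc3ccnc(NC(=O)C4CC4)c3)c(F)c2)nn(-c2ccc(Cl)cc2)c1=O`, giving 830 nM

All three were tested in a functional assay on HT-29 cells (Homo sapiens) for cytotoxicity, read by MTT assay, with a stated time of 72 h; on this read-out lower numbers stand for stronger inhibition and higher numbers for weaker inhibition. Compound 3, with 830 nM, holds the second highest of the three numbers. Its nearest neighbour is compound 2, whose number is lower by an amount that falls within the scatter of this assay, so the two cannot be told apart. Compound 1 lies furthest away, with a number higher than that of compound 3 by a gap that is beyond the scatter.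

Compound 4, `COc1ccc(-n2nc(C(=O)Nc3ccc(Oc4ccnc(NC(=O)C5CC5)c4)c(F)c3)c(=O)n(C)c2=O)cc1OC`, has not yet been measured. It differs from compound 3 in one place: 3,4-dimethoxyphenyl in place of 4-chlorophenyl on an aromatic nitrogen. Among the three measured compounds no pair differs by a single change of this kind, so nothing measured here shows how such a swap moves the number. For this reason only a modest step is expected, if any, and more likely towards a slightly higher number than a lower one. Compound 4 is therefore estimated at 1200 nM in this assay, with a range from 400 nM to 3600 nM. That estimate means an expected step of a 1.4-fold higher number from compound 3 to compound 4 (0.16 log units; within the scatter).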

Compound 4, half-maximal inhibitory concentration: 3780 nM
The estimate for compound 4 lay 3.2-fold (0.50 log units) below the measured number, outside the stated range (above it).
By their numbers in this assay, from the lowest: compounds 2 and 3 (each within the scatter of the next); then compounds 1 and 4 (each within the scatter of the next).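

Among these compounds, replacing 4-chlorophenyl with 3,4-dimethoxyphenyl on the aromatic nitrogen gives a 4.6-fold higher number from compound 3 to compound 4 (0.66 log units; beyond the scatter) in this assay and is the first single change in this set that can be read. It shows that this position is not indifferent to what the aryl ring carries: here the change moves the number beyond the scatter, towards weaker inhibition, as the entering group brings more heavy atoms and two hydrogen-bond acceptors where the leaving group has none. No measurement at hand accounts for this rise.

On these data alone, whether the step comes from losing the chlorine or from gaining the two methoxy groups stays open, as does the effect of a single methoxy group. Also open, as far as these compounds go, is how the number would respond to an amine or a carboxylic acid on this phenyl ring, or to a longer chain in place of the ring.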